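Moving a Methoxy Group Across Two Related Cores

The source may hold more compounds than are shown below. What is called first, only, known or untested is meant among the compounds shown, and "the series" means these compounds.

Compound 1 `COc1ccccc1-n1nc(C(=O)NCC(=O)Nc2nc3ccccc3s2)c2ccccc2c1=O` and compound 2 `COc1ccc(-n2nc(C(=O)NCC(=O)Nc3nc4ccccc4s3)c3ccccc3c2=O)cc1` share one core and differ only in the aryl group carried on an aromatic nitrogen: 4-methoxyphenyl in place of 2-methoxyphenyl on an aromatic nitrogen. In an assay on L cells for inhibition of Protein-serine O-palmitoleoyltransferase porcupine (Mus musculus), read by reporter gene assay, with a stated time of 24 h (a lower number here means that less compound is needed, a higher number that more compound is needed for the effect), compound 1 gives 10000 nM, while compound 2 gives 25000 nM, so that a 2.5-fold higher number from compound 1 to compound 2 (0.40 log units; beyond the scatter). Compound 3 `COc1ccccc1-n1c(SCC(=O)Nc2nc3ccc(C(F)(F)F)cc3s2)nc2c(c1=O)SCC2` is built on another core; the difference between the two cores is not broken down here. In this assay compound 3 gives 30 nM, the lowest number among the three measured compounds. Compound 4 `COc1ccc(-n2c(SCC(=O)Nc3nc4ccc(C(F)(F)F)cc4s3)nc3c(c2=O)SCC3)cc1` stands to compound 3 as compound 2 stands to compound 1: 4-methoxyphenyl in place of 2-methoxyphenyl on an aromatic nitrogen. This is the same kind of change rather than the same change, since in compound 3 the place is ortho to a large group and two atoms from the ring nitrogen, whereas in compound 1 it is next to the ring nitrogen and meta to a large group. Compound 4 is expected to show a 2.5-fold higher number from compound 3 to compound 4 (0.40 log units; beyond the scatter) in this assay because a 2.5-fold higher number from compound 1 to compound 2 (0.40 log units; beyond the scatter), a modest rise in the number. Compound 4 is accordingly estimated at 75 nM, with a likely range from 25 nM to 300 nM.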

Compound 4, half-maximal effective concentration: 100 nM
Compound 4: middle estimate off by 1.3-fold (0.12 log units), on the low side; measured number inside the range.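

In this assay, 4-methoxyphenyl in place of 2-methoxyphenyl on the second core gives a 3.3-fold higher number from compound 3 to compound 4 (0.52 log units; beyond the scatter), and set beside the earlier step, the change carries over in direction and in size: the same change on two cores in this assay, a 2.5-fold higher number (0.40 log units; beyond the scatter) from compound 1 to compound 2 and a 3.3-fold higher number (0.52 log units; beyond the scatter) from compound 3 to compound 4, 1.3-fold (0.12 log units) apart, within the scatter of two such steps. For these two matched pairs, then, the penalty for 4-methoxyphenyl appears on both cores and cannot be told apart between them, even though the numbers on the second core lie in a much lower range. This does not show that the step would hold on any further core, since two pairs make no general rule, and it does not explain why the 2-methoxyphenyl compound gives the lower number in each pair.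

The compounds shown leave open whether the same step would appear with a different group on the aryl ring, such as a hydroxyl, an amine or a fluorine in place of the methoxy group. They also leave open which of the several differences between the two cores accounts for the gap in range.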